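Adding a chloropyridinyl group to a weak oxadiazole ketone

A few compounds are considered here, and "the series" means these few. Any claim that something is new, unique, unknown or untested is made for them only; others in the source may bear on it.

The measured compounds so far:
compound 1, `O=C(CCCCCCc1ccccc1)c1nncs1`, > 10000 nM in an assay on HEK-293T cells for inhibition of diacylglycerol lipase-alpha (Homo sapiens), read by colorimetric assay; a lower number here means a stronger inhibitor, a higher number a weaker inhibitor
compound 2, `O=C(CCCCCCc1ccccc1)c1nc(Cl)co1`, 2400 nM in this assay
compound 3, `O=C(CCCCCCc1ccccc1)c1ncno1`, > 10000 nM in this assay

All three share a carbonyl carrying a long chain ending in a benzene ring, and differ only in the five-membered ring attached to that carbonyl. For compound 3 the number given is a limit of the assay, not a number, so it cannot be placed exactly; it shares this position with compound 1, as the limit of > 10000 nM in this assay, at which 2 of the 3 values shown sit, shows. Compound 2 alone gives a real number, and the step of an at least 4.1-fold higher number from compound 2 to compound 3 (0.61 log units; beyond the scatter) shows that compound 3 is weaker than compound 2 by a margin beyond the scatter. The step of an at least 4.1-fold lower number from compound 1 to compound 2 (0.61 log units; beyond the scatter) points the same way for compound 1 against compound 2.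

The unmeasured compound 4, `O=C(CCCCCCc1ccccc1)c1nc(-c2cccc(Cl)n2)no1`, differs from compound 3 by 6-chloropyridin-2-yl in place of hydrogen on an aromatic carbon. For the measured compounds named here, no measured step adds a group of this kind, so the only guide is that compound 3 sits at a limit and a substantial gain is needed to bring a number within reach. The step of an at least 25-fold lower number from compound 3 to compound 4 (1.39 log units; beyond the scatter) is therefore an expectation, not a measurement. Compound 4 is estimated at 400 nM, within 40 nM to 5000 nM.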

Compound 4, half-maximal inhibitory concentration: > 10000 nM
Compound 4: a limit, no number (the forecaster's own chance of this, stated with the estimate: 20%); middle value at least 25-fold (1.39 log units) from the limit.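

In this assay compound 4 gives > 10000 nM, which is a limit of the assay and not a number. Compound 3 and compound 4 sit at the same limit, so the step between them cannot be read: the limit of > 10000 nM in this assay, at which 3 of the 4 values shown sit.

The compounds shown leave open whether 6-chloropyridin-2-yl in place of hydrogen changes inhibition at all.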